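Removing the ethylamino group from a pyridine-bearing chromanol

A few compounds are considered here, and "the series" means these few. Any claim that something is new, unique, unknown or untested is made for them only; others in the source may bear on it.

Measured so far:
compound 1 `Cc1c(C)c2c(c(C)c1O)CCC(C)(C(=O)N1CCN(c3ncccn3)CC1)O2` — 23000 nM
compound 2 `CCNc1cccnc1N1CCN(CC2(C)CCc3c(C)c(O)c(C)c(C)c3O2)CC1` — 1000 nM

In a functional assay (brain) for inhibition, with Rattus norvegicus as the target (a higher number here means a weaker inhibitor, a lower number a stronger inhibitor), compound 2 gives the lowest of the two numbers; compound 1 gives a number that lies beyond the scatter above it, though the two structures differ in several places and no single step between them is shown. Compound 3 `Cc1c(C)c2c(c(C)c1O)CCC(C)(CN1CCN(c3ccccn3)CC1)O2` carries the change (hydrogen in place of ethylamino on an aromatic carbon). With no shown step to guide it, the move from compound 2 to compound 3 is expected to weaken inhibition by a 3.0-fold higher number from compound 2 to compound 3 (0.48 log units; beyond the scatter), somewhat beyond the scatter. Compound 3 is therefore expected to give 3000 nM in this assay, with a range from 800 nM to 12000 nM.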

Compound 3, half-maximal inhibitory concentration: 1000 nM
Compound 3: middle estimate off by 3.0-fold (0.48 log units), on the high side, and the stated range covers the measured number.
By their numbers in this assay, from the lowest: compounds 2 and 3 (each within the scatter of the next); then compound 1.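

In this assay, replacing the ethylamino group with hydrogen gives no change at the digits printed from compound 2 to compound 3 (within the scatter). At this place, on an aromatic carbon two atoms from the ring nitrogen, the ethylamino group can therefore be removed without a measurable effect on the number, so inhibition at this level does not depend on it. The data shown offer no independent evidence that would explain this result. As far as these compounds go, whether a different group here, such as a methoxy group, a carboxylic acid or a longer butylamino chain, would move the number remains open. So does whether hydrogen and ethylamino would also match at the other positions of this ring.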